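Swapping a Fluorophenyl for a Nitrophenyl on the Amide

The compounds below may be only part of what the source reports. "The series", "measured", "known", "first", "only" and "open" are said of these compounds alone.

Compound 1 `O=C(CSc1nc(Nc2ccccc2)c2ccccc2n1)Nc1ccccc1F` stands second highest of three numbers in a functional assay on NCI-H1975 cells (Homo sapiens) for inhibition, read by MTT assay, with a stated time of 72 h (a lower number here means a stronger inhibitor, a higher number a weaker inhibitor), where compound 1 gives 9350 nM. Its nearest neighbour is compound 3 `C=CC(=O)Nc1cccc(NC(=O)CSc2nc(Nc3ccccc3)c3ccccc3n2)c1`, which gives 8120 nM, and the furthest is compound 2 `O=C(CSc1nc(Nc2ccccc2)c2ccccc2n1)Nc1cccc([N+](=O)[O-])c1`, which gives 17900 nM. The unmeasured compound 4 `O=C(CSc1nc(Nc2ccccc2)c2ccccc2n1)Nc1ccc([N+](=O)[O-])cc1` differs from compound 1 by 4-nitrophenyl in place of 2-fluorophenyl on an amide-type nitrogen. The step that bears most on this is a 1.9-fold higher number from compound 1 to compound 2 (0.28 log units; within the scatter), where a nitro group also entered the phenyl ring on the amide-type nitrogen, there as 3-nitrophenyl; it stayed within the scatter. For compound 4 a similarly small shift towards a higher number is therefore expected, a 1.5-fold higher number from compound 1 to compound 4 (0.18 log units; within the scatter). Compound 4 is estimated at 14000 nM, with a range from 6000 nM to 33000 nM.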

Compound 4, half-maximal inhibitory concentration: 13000 nM
For compound 4 the middle estimate is 1.1-fold (0.03 log units) above the measured one; the measured number falls inside the stated range.
By their numbers in this assay, from the lowest: compounds 3, 1, 4 and 2 (each within the scatter of the next, the first and the last beyond it).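

On the amide-type nitrogen, 4-nitrophenyl cannot be told apart from 2-fluorophenyl or from 3-((vinylcarbonyl)amino)phenyl in this assay (a 1.4-fold higher number from compound 1 to compound 4 (0.14 log units; within the scatter) and a 1.6-fold higher number from compound 3 to compound 4 (0.20 log units; within the scatter)). Nor does the choice between 3-nitrophenyl and 4-nitrophenyl register (a 1.4-fold lower number from compound 2 to compound 4 (0.14 log units; within the scatter)), so these two nitro isomers read alike here. Nothing measured here offers an explanation for these numbers.

Still open, from the compounds shown here alone, is whether an amine or a carboxylic acid on this phenyl ring, or a longer chain in its place, would give a step beyond the scatter.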